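A few compounds are considered here, and "the series" means these few. Any claim that something is new, unique, unknown or untested is made for them only; others in the source may bear on it.

In an ADME assay on Huh-7 cells (Homo sapiens) for cytotoxicity, with a stated time of 72 h (a higher number here means that more compound is tolerated, a lower number that less compound is tolerated), compound 1 (`COC(C)(C)CCn1nc(-c2cccs2)c(O)c(C2=NS(=O)(=O)c3cc(NS(C)(=O)=O)ccc3N2)c1=O`) gives > 33000 nM as a limit of the assay. Compound 2 (`CC(C)Cn1nc(-c2cccs2)c(O)c(C2=NS(=O)(=O)c3cc(NS(C)(=O)=O)ccc3N2)c1=O`) gives > 1000 nM as a limit too, so its standing is known only as a limit. Within the data shown here, the single measured step that the two limits leave unreadable from compound 1 to compound 2 has no readable size and shows no direction. Compound 3 (`CS(=O)(=O)Nc1ccc2c(c1)S(=O)(=O)N=C(c1c(O)c(-c3cccs3)nn(CC3(C(F)(F)F)CC3)c1=O)N2`) differs from compound 2 as follows: 1-(trifluoromethyl)cyclopropyl in place of isopropyl on a saturated chain carbon bound to an aromatic nitrogen on a saturated chain carbon bound to an aromatic nitrogen. Among the measured compounds shown here, no measured step sets a size here, and the expected step that the limit leaves unreadable from compound 2 to compound 3 is a loose estimate that rests on the two limits alone. Compound 3 is estimated at 20000 nM with an expected range of 4000 nM to 60000 nM and may well return only a limit.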

Compound 3, half-maximal cytotoxic concentration: > 1000 nM
Compound 3: no number, only a limit (the forecaster's own chance of this, stated with the estimate: 80%); the middle value lies beyond the limit too.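

In this assay, among these compounds, compound 3 gives > 1000 nM, a limit of the assay, so no step among compound 1, compound 2 and compound 3 can be read. Still open, going by these compounds, is whether isopropyl, 2-methoxy-2-methylpropyl and 1-(trifluoromethyl)cyclopropyl differ at all in this assay.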